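This account rests on a few compounds, and the source may have more. Where it says the series, first, only, none or still open, it means among the compounds named here.

Measured compounds:
- compound 1 `CNC(=O)N1CCCc2ccc(NC(=O)c3ccc(-c4ccccc4)cc3)cc21` gives 74.3% in a functional assay on MV4-11 cells (Homo sapiens) for antiproliferative activity, with a stated time of 6 days, tested at 6.25 uM; a lower number here means a weaker effect, a higher number a stronger effect of the compound at the concentration tested
- compound 2 `CNC(=O)N1CCCc2ccc(NC(=O)c3ccccc3-c3ccccc3)cc21` gives 60.4% in this assay

Of these two numbers, compound 1 stands highest; compound 2 sits below it by a gap that lies beyond the usual scatter of the measurement. Going by the values given here, with only two compounds measured, nothing more than this can be read from the data.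

Compound 3 `CNC(=O)N1CCCc2ccc(NC(=O)c3ccc(-c4cnn(C)c4)cc3)cc21` is not yet measured. It differs from compound 1 in a single place: 1-methyl-1H-pyrazol-4-yl in place of phenyl on an aromatic carbon. Among the compounds with values here, no pair of measured compounds carries this change, so its effect must be estimated without a measured precedent. The expectation is that the step of a number 4.3 percentage points lower from compound 1 to compound 3 (within the scatter) is small, with no move beyond the scatter in either direction. For compound 3 the estimate in this assay is therefore 70%, expected to fall between 45% and 90%.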

Compound 3, a percentage reported as inhibition, at one concentration (the size of the read-out at that concentration, not a potency): 94.4%
Compound 3: the middle estimate sits 24.4 percentage points below what was measured; measured number outside the range, above it.
By their numbers in this assay, from the lowest: compound 2; then compound 1; then compound 3.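

The step of a number 20.1 percentage points higher from compound 1 to compound 3 (beyond the scatter) in this assay comes from placing 1-methyl-1H-pyrazol-4-yl in place of phenyl on the aromatic carbon para to a large group. It shows that this position does not need a six-membered aromatic ring of carbon only, since a five-membered aromatic ring with 2 hetero atoms raises the read-out beyond the scatter. Both groups have 6 heavy atoms, so the step comes with a change in ring and atoms rather than in heavy-atom count, but nothing shown accounts for the gain.

As far as these compounds go, whether the methyl on the pyrazole contributes to this read-out remains open, as does how a plain 1H-pyrazol-4-yl or a pyridin-3-yl ring would compare at this position. From the compounds shown here alone, the read-out also comes from one concentration, so the potency of compound 3 remains open.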